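Adding a Methoxy to Compound 1

The compounds below may be only part of what the source reports. "The series", "measured", "known", "first", "only" and "open" are said of these compounds alone.

compound 1 `COc1ccc(C(=O)/C=C/c2ccccc2-c2ccc(F)cc2)cc1`: 9000 nM
compound 2 `COc1ccc(C(=O)/C=C/c2ccccc2-c2ccc(F)nc2)cc1`: 13000 nM

In a functional assay on CNE-2 cells (Homo sapiens) for antiproliferative activity, read by sulforhodamine B assay, with a stated time of 48 h (on this read-out lower numbers stand for stronger inhibition and higher numbers for weaker inhibition), compound 1 and compound 2 lie within the scatter of each other, so compound 1 holds no clear rank. Compound 3 `COc1ccc(C(=O)/C=C/c2ccccc2-c2ccc(F)cc2)cc1OC` differs from compound 1 by methoxy in place of hydrogen on an aromatic carbon in the form of methoxy in place of hydrogen on an aromatic carbon. Among the measured compounds shown here, the one measured step of a 1.4-fold higher number from compound 1 to compound 2 (0.16 log units; within the scatter) concerns a different change, so it offers only indirect guidance. It gives no firm direction, and the expected step of a 1.3-fold lower number from compound 1 to compound 3 (0.11 log units; within the scatter) in this assay stays within the scatter. Compound 3 is estimated at 7000 nM with a range from 2500 nM to 20000 nM in this expectation.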

Compound 3, half-maximal inhibitory concentration: 7600 nM
For compound 3 the middle estimate is 1.1-fold (0.04 log units) below the measured one, and the stated range covers the measured number.
By their numbers in this assay, from the lowest: compounds 3, 1 and 2 (each within the scatter of the next).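

In this assay, methoxy in place of hydrogen on an aromatic carbon, ortho to a methoxy group and meta to a large group, gives a 1.2-fold lower number from compound 1 to compound 3 (0.07 log units; within the scatter). Among the compounds shown here, this is the first reading at this position, and it shows that the added methoxy leaves the two compounds within the scatter of each other. The compounds shown leave open whether a hydroxyl, an amine or a carboxylic acid at this same position would give a step beyond the scatter. No evidence on hand bears on this result.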